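Phenyl to Cyclopentyl on the Amide of a Fluorinated Core

A few compounds are considered here, and "the series" means these few. Any claim that something is new, unique, unknown or untested is made for them only; others in the source may bear on it.

Measured compounds:
compound 1, `C#CCn1cc(C(=O)NC(CC(=O)Nc2ccccc2)c2ccccc2)c(=O)c2cc(F)c(Cl)nc21`, 5700 nM
compound 2, `C#CCn1cc(C(=O)NC(CC(=O)Nc2ccccc2)c2ccccc2)c(=O)c2ccc(Cl)nc21`, 2900 nM
compound 3, `C#CCn1cc(C(=O)NC(CC(=O)NC2CCCC2)c2ccccc2)c(=O)c2ccc(Cl)nc21`, 2700 nM

All three were tested in a functional assay on SW-620 cells (Homo sapiens) for cytotoxicity, read by MTT assay, with a stated time of 72 h; on this read-out higher numbers stand for weaker inhibition and lower numbers for stronger inhibition. Compound 1 gives the largest of the three numbers; its gap to compound 2 lies within the scatter, and only its gap to compound 3 lies beyond it, so compound 1 cannot be called the weakest with confidence. The two measured steps are small: a 2.0-fold lower number from compound 1 to compound 2 (0.29 log units; within the scatter), and a 1.1-fold lower number from compound 2 to compound 3 (0.03 log units; within the scatter).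

Compound 4, `C#CCn1cc(C(=O)NC(CC(=O)NC2CCCC2)c2ccccc2)c(=O)c2cc(F)c(Cl)nc21`, has not yet been measured. It differs from compound 1 in one place: cyclopentyl in place of phenyl on an amide-type nitrogen. The step from compound 2 to compound 3 is the same exchange on the core without fluoro, and there it was within the scatter. The move from compound 1 to compound 4 is therefore expected to show no step beyond the scatter in this assay, so that a 1.1-fold lower number from compound 1 to compound 4 (0.04 log units; within the scatter) is the expected outcome. The number for compound 4 in this assay is accordingly estimated at 5200 nM, within a range from 2600 nM to 10400 nM.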

Compound 4, half-maximal inhibitory concentration: 2100 nM
Estimate against measurement, compound 4: 2.5-fold (0.39 log units) above, and the stated range ends above it.
By their numbers in this assay, from the lowest: compounds 4, 3, 2 and 1 (each within the scatter of the next, the first and the last beyond it).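

Among the compounds shown here, with cyclopentyl in place of phenyl on the amide-type nitrogen, this assay now shows a 2.7-fold lower number from compound 1 to compound 4 (0.43 log units; beyond the scatter), the first step of this exchange that lies beyond the scatter, yet the data do not show that its size depends on the core: the same change on two cores in this assay, a 1.1-fold lower number (0.03 log units; within the scatter) from compound 2 to compound 3 and a 2.7-fold lower number (0.43 log units; beyond the scatter) from compound 1 to compound 4, 2.5-fold (0.40 log units) apart, within the scatter of two such steps. Fluoro in place of hydrogen on an aromatic carbon gives a 1.3-fold lower number from compound 3 to compound 4 (0.11 log units; within the scatter), and this change likewise does not differ readably between the phenyl and cyclopentyl compounds: the same change on two cores in this assay, a 2.0-fold lower number (0.29 log units; within the scatter) from compound 1 to compound 2 and a 1.3-fold higher number (0.11 log units; within the scatter) from compound 4 to compound 3, 2.5-fold (0.40 log units) apart, within the scatter of two such steps. With cyclopentyl on the amide-type nitrogen, the fluoro therefore leaves the number within the scatter.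

On these data alone, whether a cyclohexyl or benzyl group, or a chain bearing an amine or a carboxylic acid, on that nitrogen would lower the number further remains open. As far as these compounds go, all four numbers also come from a single cell line, so how far these steps carry to other cells is unknown.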